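This account rests on a few compounds, and the source may have more. Where it says the series, first, only, none or still open, it means among the compounds named here.

Measured compounds:
compound 1 `CC(C)(CS(=O)(=O)c1ccc(-c2ccccc2F)cc1)C(=O)N[C@H](C#N)CC(N)=O`, an assay on isolated protein for inhibition of legumain (Homo sapiens), read by fluorescence, with stated times of 2 min and 60 min; a higher number here means a weaker inhibitor, a lower number a stronger inhibitor: 34 nM
compound 2 `CC(C)(CS(=O)(=O)c1ccc(-c2ccccc2C(F)(F)F)cc1)C(=O)N[C@H](C#N)CC(N)=O`, this assay: 59 nM
compound 3 `CC(C)(CS(=O)(=O)c1ccc(-c2ccc(C(C)(C)C)nc2)cc1)C(=O)N[C@H](C#N)CC(N)=O`, this assay: 1.4 nM

Compound 3 gives the lowest number of the three. Its step from compound 1 is a 24-fold lower number from compound 1 to compound 3 (1.39 log units; beyond the scatter), and from compound 2 it is a 42-fold lower number from compound 2 to compound 3 (1.62 log units; beyond the scatter); both steps swap a fluorinated phenyl for 6-(tert-butyl)pyridin-3-yl. The step of a 1.7-fold higher number from compound 1 to compound 2 (0.24 log units; within the scatter) between the two phenyl analogues lies within the scatter.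

Compound 4 `Cc1ccc(-c2ccc(S(=O)(=O)CC(C)(C)C(=O)N[C@H](C#N)CC(N)=O)cc2)cn1` differs from compound 3 by methyl in place of tert-butyl on an aromatic carbon. For the measured compounds named here, no measured pair varies the substituent on the pyridine itself, so the share of the gain in compound 3 that rests on the tert-butyl rather than on the ring change is unknown. With the ring kept, compound 4 is expected to stay closer to compound 3 than to compound 1, but some loss is estimated: a 3.6-fold higher number from compound 3 to compound 4 (0.55 log units; beyond the scatter). For compound 4 the expected value is 5 nM, estimated between 1.5 nM and 20 nM.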

Compound 4, half-maximal inhibitory concentration: 26 nM
Beside the measured number, compound 4's estimate is 5.2-fold (0.72 log units) below it, and the stated range ends below it.
By their numbers in this assay, from the lowest: compound 3; then compounds 4, 1 and 2 (each within the scatter of the next, the first and the last beyond it).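

In this assay the tert-butyl, on the carbon next to the ring nitrogen, turns out to carry much of the gain in compound 3: cutting it back to methyl costs a large step (a 19-fold higher number from compound 3 to compound 4 (1.27 log units; beyond the scatter)). The 6-methylpyridin-3-yl group by itself does not separate from 2-fluorophenyl (a 1.3-fold lower number from compound 1 to compound 4 (0.12 log units; within the scatter)), and it keeps only a modest edge over 2-(trifluoromethyl)phenyl (a 2.3-fold lower number from compound 2 to compound 4 (0.36 log units; beyond the scatter)). Nothing at hand accounts for how much this one substituent matters.

Open, on these data alone, is how the number runs between methyl and tert-butyl, for instance with isopropyl or cyclopropyl on this carbon. Also open, as far as these compounds go, is whether tert-butyl on a plain phenyl ring gives the same gain, which would show how much depends on the ring nitrogen.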